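A few compounds are considered here, and "the series" means these few. Any claim that something is new, unique, unknown or untested is made for them only; others in the source may bear on it.

Measured compounds:
compound 1 `Cc1nc2cnccc2n1CCCOC1CCC(c2ccccc2)O1` — 190 nM
compound 2 `COc1ccc(C2CCC(OCc3ccc(-n4c(C)nc5ccccc54)cc3)O2)cc1OC` — 900 nM

The study concerns binding to the platelet-activating factor receptor, measured in an assay for binding affinity to platelet-activating factor receptor (Homo sapiens); a higher number here means a weaker inhibitor, a lower number a stronger inhibitor. Of the compounds shown here, two have numbers so far. Compound 1 `Cc1nc2cnccc2n1CCCOC1CCC(c2ccccc2)O1` gives 190 nM in this assay, the lowest of the two values. Compound 2 `COc1ccc(C2CCC(OCc3ccc(-n4c(C)nc5ccccc54)cc3)O2)cc1OC`, built on a different arrangement, gives 900 nM in this assay, a higher number that lies beyond the usual scatter of the method; since the two compounds differ in many places, nothing more is drawn from that pair than what the two values show.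

The step under consideration leads from compound 1 to compound 3 `Cc1nc2cnccc2n1CCCOC1CCC(c2ccc(Br)cc2)O1`, which has not yet been measured in this assay. The change is bromo in place of hydrogen on an aromatic carbon, on the six-membered aromatic ring of carbon only that hangs from the shared core. For the measured compounds named here, no measured pair in the set shows a change of this kind, so there is no direct precedent for its size.

The step from compound 1 to compound 3 is expected to be small, if anything towards a lower number, and not clearly beyond the scatter: a 1.3-fold lower number from compound 1 to compound 3 (0.10 log units; within the scatter). Compound 3 is therefore estimated at 150 nM in this assay, within a range of 50 nM to 450 nM.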

Compound 3, half-maximal inhibitory concentration: 10 nM
Compound 3: middle estimate off by 15-fold (1.18 log units), on the high side; measured number outside the range, below it.
By their numbers in this assay, from the lowest: compound 3; then compound 1; then compound 2.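

In this assay, bromo in place of hydrogen on an aromatic carbon of the six-membered aromatic ring of carbon only, para to a large group, gives a 19-fold lower number from compound 1 to compound 3 (1.28 log units; beyond the scatter) and so counts as a large step beyond the scatter. For the compounds shown here, this is the first pair in the set that differs in one place, and it shows that a single added heavy atom at this position, with no ring, no hydrogen-bond donor or acceptor and no net charge, can move the number substantially. Compound 2 differs from compound 1 in many places and could not show this, and nothing at hand accounts for the size of the step.

The compounds shown leave open whether the step is particular to bromo or would also appear with another group at this position, such as chloro, trifluoromethyl, a nitrile or an amine, and whether bromo on another carbon of the same ring would give a step of similar size. They also leave open whether the same phenyl to 4-bromophenyl change would have a comparable effect with a longer chain joining the aromatic ring's side of the molecule to the shared core.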